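The source may report more compounds than this note shows. Statements on the series, on what has been measured and on what is new or still open speak of the compounds shown alone.

Measured so far:
- compound 1, `CCOC(=O)/C(=N\O)c1ccc(Sc2cc(F)cc(C3CCOCC3)c2)cc1`: 170 nM
- compound 2, `CO[C@]1(c2cc(F)cc(S(=O)(=O)c3ccc(/C(C)=N/O)cc3)c2)CCO[C@@H](C)C1`: 20 nM

Both compounds were tested in a functional assay (blood) for inhibition, with Homo sapiens as the target; a lower number here means a stronger inhibitor, a higher number a weaker inhibitor. Among the measured compounds shown here, compound 1 stands at the highest of the two numbers; compound 2 gives the only other value, and the gap between them lies beyond the usual scatter, so compound 2 is the stronger of the two. Compound 3, `C/C(=N\OCC(=O)O)c1ccc(Sc2cc(F)cc(C3CCOCC3)c2)cc1`, has not yet been measured. It differs from compound 1 in one place: a group of 8 heavy atoms (4 carbon, 1 nitrogen, 3 oxygen; no ring) in place of a group of 8 heavy atoms (4 carbon, 1 nitrogen, 3 oxygen; no ring), on an aromatic carbon. For the measured compounds named here, no pair of measured compounds shows this kind of change, so there is nothing to read the size of the step from. A step of modest size is expected, with the direction uncertain but leaning toward a weaker inhibitor, as the move from compound 1 to compound 3 a 1.8-fold higher number from compound 1 to compound 3 (0.25 log units; within the scatter) is estimated here. Compound 3 is expected to give about 300 nM in this assay, within a range from 60 nM to 1500 nM.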

Compound 3, half-maximal inhibitory concentration: 740 nM
Compound 3: the middle estimate sits 2.5-fold (0.39 log units) below what was measured; measured number inside the range.
By their numbers in this assay, from the lowest: compound 2; then compound 1; then compound 3.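

Swapping one group for another on this aromatic carbon, para to a large group, gives a 4.4-fold higher number from compound 1 to compound 3 (0.64 log units; beyond the scatter) in this assay, so compound 3 is the weaker inhibitor. The two groups have the same heavy-atom count and the same atoms, and differ by count only in hydrogen-bond acceptors, so matching the atom count does not preserve the value at this position. Nothing available explains why this swap weakens inhibition.

This single step cannot show whether the same swap would have a similar effect on a different core, such as that of compound 2. It also leaves open how other groups at this position, such as an amide, a nitrile or a longer chain, would compare.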